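The compounds below may be only part of what the source reports. "The series", "measured", "known", "first", "only" and "open" are said of these compounds alone.

Working notes on the sulfonamide series in a functional assay on MIA PaCa-2 cells (Homo sapiens) for inhibition, read by MTT assay, with a stated time of 72 h; on this read-out higher numbers stand for weaker inhibition of growth and lower numbers for stronger inhibition of growth.

Three analogues of the shared core are measured so far, differing only in the substituent on the aromatic ring that carries the sulfonamide. Compound 1 `CCCCc1ccc(S(=O)(=O)NCCCCCCNCc2ccc(Br)cc2)cc1` gives 5700 nM. Compound 2 `CC(C)c1ccc(S(=O)(=O)NCCCCCCNCc2ccc(Br)cc2)cc1` gives 5730 nM. Compound 3 `O=S(=O)(NCCCCCCNCc1ccc(Br)cc1)c1ccc(Cl)cc1` gives 5900 nM. The three numbers sit on top of each other: the step of a 1.0-fold higher number from compound 1 to compound 2 (0.00 log units; within the scatter), the step of a 1.0-fold higher number from compound 1 to compound 3 (0.01 log units; within the scatter) and the step of a 1.0-fold higher number from compound 2 to compound 3 (0.01 log units; within the scatter) all lie within the scatter, so compound 3 holds the highest number of the three only in the nominal sense, and no order among them can be read.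

The next compound, compound 4 `Cc1ccc(S(=O)(=O)NCCCCCCNCc2ccc(Br)cc2)cc1`, differs from compound 3 in one place: methyl in place of chloro on an aromatic carbon. The substituent stays on the aromatic carbon para to a large group, as in the other three.

Among the compounds with values here, the steps that bear on the change are those among compounds 1, 2 and 3, where butyl, isopropyl and chloro were exchanged at this position with no movement beyond the scatter. A fourth small group at the same place gives no reason to expect anything different, so the step from compound 3 to compound 4 is expected to be a 1.0-fold higher number from compound 3 to compound 4 (0.01 log units; within the scatter), within the scatter.

Compound 4 is therefore estimated at 6000 nM in this assay, with a range from 3000 nM to 12000 nM.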

Compound 4, concentration for 50% growth inhibition: 12300 nM
The estimate for compound 4 lay 2.1-fold (0.31 log units) below the measured number; measured number above the stated range.
By their numbers in this assay, from the lowest: compounds 1, 2 and 3 (each within the scatter of the next); then compound 4.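

In this assay, within the data shown here, this position is no longer indifferent to the group it carries: a 2.1-fold higher number from compound 3 to compound 4 (0.32 log units; beyond the scatter) is the first step here to pass beyond the scatter, and a 2.1-fold higher number from compound 2 to compound 4 (0.33 log units; beyond the scatter) and a 2.2-fold higher number from compound 1 to compound 4 (0.33 log units; beyond the scatter) are of the same modest size. Butyl, isopropyl and chloro remain within the scatter of one another, so methyl alone departs among the four groups, towards weaker inhibition of growth. The change from 4-chlorophenyl to 4-methylphenyl leaves the heavy-atom count, the absence of a ring, the hydrogen-bond donor and acceptor counts and the net charge as they were, so none of these counted features separates compound 3 from compound 4.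

No measurement shown here accounts for the separation of compound 4 from the other three. Still open, from the compounds shown here alone, is whether a hydrogen, a methoxy group, an amine or a carboxylic acid at this place would stay with compounds 1, 2 and 3 or move with compound 4, and whether a step of this modest size holds on repeated measurement.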